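A few compounds are considered here, and "the series" means these few. Any claim that something is new, unique, unknown or untested is made for them only; others in the source may bear on it.

Measured in a functional assay on L1210 cells (Mus musculus) for inhibition; a lower number here means a stronger inhibitor, a higher number a weaker inhibitor:
- compound 1 `O=C1/C(=C/c2cccc(Br)c2)Cc2ccccc21` gives 43300 nM
- compound 2 `Cc1cccc(/C=C2\Cc3ccccc3C2=O)c1` gives 50400 nM
- compound 3 `O=C1/C(=C/c2ccc(Br)cc2)CCc2ccccc21` gives 202000 nM

Compound 3 has the highest number of the three, beyond the scatter from both compound 1 and compound 2, so it is the weakest inhibitor of the set. The next compound, compound 4 `CN(C)c1ccc(/C=C2\CCc3ccccc3C2=O)cc1`, carries dimethylamino in place of bromo on an aromatic carbon, para to a large group (dimethylamino in place of bromo on an aromatic carbon).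

For the measured compounds named here, only one measured step bears on this change, a replacement of the same bromo by a different group, methyl (a 1.2-fold higher number from compound 1 to compound 2 (0.07 log units; within the scatter)). That step lies within the scatter, but it was measured on the core of compound 1, and methyl is not dimethylamino, so it is weak guidance. Going by the values given here, no measured step shows what dimethylamino does. No change beyond the scatter is therefore expected in this assay, and the expected step is small (a 1.3-fold lower number from compound 3 to compound 4 (0.13 log units; within the scatter)). In this assay, compound 4 is estimated at 150000 nM, with an expected range from 50000 nM to 400000 nM.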

Compound 4, half-maximal inhibitory concentration: 17500 nM
Compound 4: middle estimate off by 8.6-fold (0.93 log units), on the high side, and the stated range ends above it.
By their numbers in this assay, from the lowest: compound 4; then compounds 1 and 2 (each within the scatter of the next); then compound 3.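

In this assay, dimethylamino in place of bromo on an aromatic carbon, para to a large group, brings a large drop in the number (a 12-fold lower number from compound 3 to compound 4 (1.06 log units; beyond the scatter)). For the compounds shown here, this is the first single-place change that lies beyond the scatter; methyl in place of bromo on the core of compound 1 stayed within it (a 1.2-fold higher number from compound 1 to compound 2 (0.07 log units; within the scatter)). The aromatic carbon carrying bromo in compound 3 is therefore not indifferent to the group it holds, at least on the core shared by compound 3 and compound 4, but nothing at hand accounts for the size of the step.

Open, going by these compounds, is whether a primary amine or a methoxy group at this carbon gives a step of similar size. Also open, on these data alone, is whether dimethylamino has the same effect on the core of compound 1.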